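Trading Chlorophenyl for Methylphenyl on the Nitrogen

The compounds below may be only part of what the source reports. "The series", "measured", "known", "first", "only" and "open" are said of these compounds alone.

Compound 1 `Cc1nc(Nc2ccc(Cl)cc2)sc1C(=O)/C=C/c1ccccc1` was tested in a functional assay on Bel-7402 cells (Homo sapiens) for cytotoxicity, read by MTT assay; a higher number here means a weaker inhibitor, a lower number a stronger inhibitor. In this assay compound 1 gives > 25000 nM, which is a limit of the assay and not a number. Two relatives differ from it only on the aryl ring at the end of the double-bonded chain. Compound 2 `COc1cccc(/C=C/C(=O)c2sc(Nc3ccc(Cl)cc3)nc2C)c1` carries a methoxy in place of hydrogen on an aromatic carbon, and in this assay compound 2 gives > 25000 nM, again a limit. Compound 3 `Cc1nc(Nc2ccc(Cl)cc2)sc1C(=O)/C=C/c1ccc(Cl)cc1` carries a chloro in place of hydrogen on an aromatic carbon, and in this assay compound 3 gives > 25000 nM, also a limit. The steps a step that the two limits leave unreadable from compound 1 to compound 2, a step that the two limits leave unreadable from compound 1 to compound 3 and a step that the two limits leave unreadable from compound 2 to compound 3 cannot be sized because of the limit of > 25000 nM in this assay, at which 3 of the 3 values shown sit.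

Compound 4 `Cc1ccccc1Nc1nc(C)c(C(=O)/C=C/c2ccccc2)s1` changes the other end of the molecule: 2-methylphenyl in place of 4-chlorophenyl on a nitrogen on an aromatic ring. For the measured compounds named here, none of the measured steps touches this nitrogen, and none of them has a readable size, so they offer no direction for the new change. Compound 4 is therefore expected to give 30000 nM, within a range of 10000 nM to 100000 nM, most likely again reported as a limit. The step this estimate implies, a step that the limit leaves unreadable from compound 1 to compound 4, is expected to lie within the scatter.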

Compound 4, half-maximal inhibitory concentration: > 25000 nM
Compound 4 gave a limit, no number (the forecaster's own chance of this, stated with the estimate: 75%); the middle value is on the limit's open side.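

The step from compound 1 to compound 4 cannot be read, and neither can any other step among the compounds shown, because each value is a limit and not a number: the limit of > 25000 nM in this assay, at which 4 of the 4 values shown sit.

From the compounds shown here alone, it remains open whether changing either end of these molecules can shift the result in this assay at all, and in which direction.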